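Dichlorophenyl amide regioisomers in a pyrazole antiproliferative series

The source may hold more compounds than are shown below. What is called first, only, known or untested is meant among the compounds shown, and "the series" means these compounds.

The shared core carries an aryl pyrazole bearing a pyridyl group and a para-substituted anilide. Compound 2 `O=C(Nc1ccc(-n2cc(-c3ccncc3)c(-c3ccc(Cl)c(O)c3)n2)cc1)Nc1ccc(Cl)c(C(F)(F)F)c1` is a urea; in a functional assay on UACC-62 cells (Homo sapiens) for antiproliferative activity, read by sulforhodamine B assay, with a stated time of 48 h (a lower number here means a stronger inhibitor, a higher number a weaker inhibitor), compound 2 gives 1700 nM. Compound 3 `O=C(Nc1ccc(-n2cc(-c3ccncc3)c(-c3ccc(Cl)c(O)c3)n2)cc1)c1ccc(Cl)c(Cl)c1` replaces the urea with a dichlorobenzamide, and in this assay compound 3 gives 3220 nM; the change a 1.9-fold higher number from compound 2 to compound 3 (0.28 log units; within the scatter) stays inside the scatter. Compound 1 `COc1cc(-c2nn(-c3ccc(NC(=O)c4cc(Cl)cc(Cl)c4)cc3)cc2-c2ccncc2)ccc1Cl` carries a methoxy group in place of the hydroxyl of compound 3 together with the 3,5-dichlorophenyl amide, and in this assay compound 1 gives 4580 nM. Among the three numbers compound 3 stands second highest, with compound 1 nearest and compound 2 furthest, and both gaps lie within the scatter.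

Compound 4 `O=C(Nc1ccc(-n2cc(-c3ccncc3)c(-c3ccc(Cl)c(O)c3)n2)cc1)c1cc(Cl)cc(Cl)c1` differs from compound 3 only in the dichlorophenyl pattern: 3,5-dichlorophenyl in place of 3,4-dichlorophenyl on a carbonyl carbon. Among the compounds with values here, no measured step addresses this move of a chlorine within the amide ring; the single step on record, from compound 2 to compound 3, concerns the whole group on the carbonyl carbon. Compound 1 and compound 3 share different substitution patterns but also differ at the phenol, so their two values show only that both sit within the scatter of each other.

With nothing to argue for a shift, no step beyond the scatter is expected, so compound 4 is estimated at a 1.1-fold higher number from compound 3 to compound 4 (0.04 log units; within the scatter). The expected value for compound 4 in this assay is 3500 nM, within 1400 nM to 9000 nM.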

Compound 4, half-maximal inhibitory concentration: 2730 nM
Estimate against measurement, compound 4: 1.3-fold (0.11 log units) above, within the range that was stated.
By their numbers in this assay, from the lowest: compounds 2, 4, 3 and 1 (each within the scatter of the next, the first and the last beyond it).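

In this assay, the change of chlorine pattern at this position, 3,5-dichlorophenyl in place of 3,4-dichlorophenyl on a carbonyl carbon, gives a 1.2-fold lower number from compound 3 to compound 4 (0.07 log units; within the scatter), so the move of one chlorine within the amide ring leaves no readable difference. The new compound also gives the first single-place read at the oxygen on the aromatic ring: hydrogen in place of methyl gives a 1.7-fold lower number from compound 1 to compound 4 (0.22 log units; within the scatter), whereas compound 1 and compound 3 differ in two places and could not isolate this change. Against the urea, 3,5-dichlorophenyl in place of (4-chloro-3-(trifluoromethyl)phenyl)amino on the carbonyl carbon gives a 1.6-fold higher number from compound 2 to compound 4 (0.21 log units; within the scatter), so this dichlorophenyl amide, like the 3,4-dichlorophenyl amide, cannot be separated from the urea.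

Still open, going by these compounds, is whether an amine or a carboxylic acid in place of a chlorine on the amide ring would move the number beyond the scatter. Also open, on these data alone, is whether a longer chain on the oxygen would do so, and no measurement on hand bears on why these steps stay so small.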